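Permeability notes: furfuryl diamine series, aryl variation at the core

The compounds below may be only part of what the source reports. "The series", "measured", "known", "first", "only" and "open" are said of these compounds alone.

Measured so far:
- compound 1, `c1ccc(Oc2ccc3c(NCCCNCc4ccco4)ccnc3c2)cc1`: 317 10^-6 cm/s
- compound 2, `COc1cccc(CNCCCNc2ccnc3cc(-c4ccc(C(F)(F)F)cc4)ccc23)c1O`: 237 10^-6 cm/s

In an ADME assay for permeability, using PAMPA, with a stated time of 30 min, at pH 7.4 (a lower number here means that the compound crosses the layer more slowly, a higher number that the compound crosses the layer faster), compound 1 gives 317 10^-6 cm/s. Compound 2, which carries a different aryl group and a different benzylic amine, gives 237 10^-6 cm/s in this assay. The two numbers lie within the scatter of each other, so no order can be drawn between compound 1 and compound 2; both sit at a high apparent permeability.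

Compound 3, `Cc1cc(C)cc(Cc2ccc3c(NCCCNCc4ccco4)ccnc3c2)c1`, is not yet measured. It differs from compound 1 in one place: 3,5-dimethylbenzyl in place of phenoxy on an aromatic carbon. Among the measured compounds shown here, no step between measured compounds bears on this change, and compound 2 differs from compound 1 in more than one place, so it gives no guide to the step.

For the measured compounds named here, with both measured compounds at high apparent permeability and no reference step available, no movement beyond the scatter is expected. The step from compound 1 to compound 3 in this assay is estimated as a 1.1-fold lower number from compound 1 to compound 3 (0.02 log units; within the scatter). Compound 3 is therefore expected to give 300 10^-6 cm/s in this assay, with a range from 170 10^-6 cm/s to 520 10^-6 cm/s.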

Compound 3, apparent permeability: 23 10^-6 cm/s
Compound 3: middle estimate off by 13-fold (1.12 log units), on the high side; measured number outside the range, below it.
By their numbers in this assay, from the lowest: compound 3; then compounds 2 and 1 (each within the scatter of the next).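

This position on the shared core is not neutral in this assay: 3,5-dimethylbenzyl in place of phenoxy on an aromatic carbon gives a 14-fold lower number from compound 1 to compound 3 (1.14 log units; beyond the scatter) and separates two compounds that differ in this one place. The high number of compound 1 therefore does not hold for every group carrying a six-membered aromatic ring of carbon only at this position, although both groups have such a ring, no hydrogen-bond donors and no net charge. The groups differ in that phenoxy brings an oxygen and a hydrogen-bond acceptor, while 3,5-dimethylbenzyl brings only carbon, but no measurement here ties the step to any property of either group.

Among the compounds shown here, the single step joins two alterations, the atom linking the aromatic ring to the core and the two methyl groups on that ring, and does not tell them apart. An unsubstituted benzyl group and a 3,5-dimethylphenoxy group at this position would separate the two, while a directly attached phenyl group would show how the number responds when no linking atom is present.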